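The source may report more compounds than this note shows. Statements on the series, on what has been measured and on what is new or still open speak of the compounds shown alone.

Compound 1 `Oc1ccc(/C=C/c2ccccc2O)cc1`, compound 2 `Oc1ccc(/C=C/c2cccc(O)c2)cc1` and compound 3 `Nc1ccc(/C=C/c2ccccc2O)cc1` have been measured in a functional assay on HT-29 cells (Homo sapiens) for inhibition, read by MTT assay, with a stated time of 2 days; a higher number here means a weaker inhibitor, a lower number a stronger inhibitor. In this assay compound 1 gives 22 ug/mL, compound 2 gives 6.9 ug/mL and compound 3 gives 37 ug/mL. Compound 2 shows the lowest number of the three, beyond the scatter against both compound 1 and compound 3. Compound 1 and compound 2 contain the same atoms joined differently; the difference between the two cores is not broken down here. Compound 3 differs from compound 1 by amino in place of hydroxy on an aromatic carbon, and that step, a 1.7-fold higher number from compound 1 to compound 3 (0.23 log units; within the scatter), lies within the scatter. Compound 4 `Nc1ccc(/C=C/c2cccc(O)c2)cc1`, not yet measured, differs from compound 2 by amino in place of hydroxy on an aromatic carbon, the same change at the same place. The step from compound 2 to compound 4 is expected to be similar, about a 1.7-fold higher number from compound 2 to compound 4 (0.24 log units; within the scatter), because in compound 1 and compound 3 the change gave a 1.7-fold higher number from compound 1 to compound 3 (0.23 log units; within the scatter). Compound 4 is therefore estimated at 12 ug/mL, with a likely range from 5 ug/mL to 28 ug/mL.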

Compound 4, half-maximal inhibitory concentration: 42 ug/mL
Estimate against measurement, compound 4: 3.5-fold (0.54 log units) below; measured number above the stated range.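

In this assay amino in place of hydroxy on an aromatic carbon gives a 6.1-fold higher number from compound 2 to compound 4 (0.78 log units; beyond the scatter) and so does not repeat the size of the step seen on the core of compound 1. The size of this change therefore does not carry directly from one core to the other in this series: the same change on two cores in this assay, a 1.7-fold higher number (0.23 log units; within the scatter) from compound 1 to compound 3 and a 6.1-fold higher number (0.78 log units; beyond the scatter) from compound 2 to compound 4, 3.6-fold (0.56 log units) apart, beyond the scatter of two such steps. Among the compounds shown here, with only two matched pairs, this shows that the core matters to the size of the step, but it does not explain the gap or predict the step on any further core.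

The compounds shown leave open how methoxy, an amide or a carboxylic acid in place of the hydroxy would read on these two cores. They also leave open whether such groups would show a similar gap between the cores.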